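The source may report more compounds than this note shows. Statements on the series, on what has been measured and on what is new or still open speak of the compounds shown alone.

Within the data shown here, in a functional assay on HT-29 cells (Homo sapiens) for cytotoxicity, read by MTT assay, with a stated time of 72 h (on this read-out lower numbers stand for stronger inhibition and higher numbers for weaker inhibition), compound 1 (`COC(=O)c1sc2cc(OC)ccc2c1Nc1cc(OC)c(OC)c(OC)c1`) gives 0.9 nM and holds the middle place among the three compounds measured so far. Compound 2 (`COC(=O)c1sc2cc(C)ccc2c1Nc1cc(OC)c(OC)c(OC)c1`) lies on its higher side at 1.9 nM and compound 3 (`COC(=O)c1sc2nc(C)ccc2c1Nc1cc(OC)c(OC)c(OC)c1`) on its lower side at 0.35 nM on the same scale. Compound 4 (`CCOC(=O)c1sc2cc(OC)ccc2c1Nc1cc(OC)c(OC)c(OC)c1`) has not yet been measured. It differs from compound 1 only in the ester: methyl in place of hydrogen on a saturated chain carbon bound to an oxygen next to a carbonyl group, which turns methoxycarbonyl into ethoxycarbonyl.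

Among the measured compounds shown here, the only measured single-place step is a 2.1-fold higher number from compound 1 to compound 2 (0.32 log units; beyond the scatter) (methyl in place of methoxy on an aromatic carbon). This modest step lies elsewhere in the molecule, so it bears on the ester change only indirectly, as a guide to how far one small exchange on compound 1 has moved the number. For the measured compounds named here, no measured pair alters the ester, so the direction remains a tentative call. Judging by the size of a 2.1-fold higher number from compound 1 to compound 2 (0.32 log units; beyond the scatter) in compound 2, the expected change is a 1.8-fold higher number from compound 1 to compound 4 (0.25 log units; within the scatter) in this assay (a modest rise at most likely, possibly within the scatter). Compound 4 is therefore expected to give about 1.6 nM (estimated range 0.5 nM to 6 nM).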

Compound 4, half-maximal inhibitory concentration: 10.2 nM
Compound 4: middle estimate off by 6.4-fold (0.80 log units), on the low side; measured number outside the range, above it.
By their numbers in this assay, from the lowest: compound 3; then compound 1; then compound 2; then compound 4.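

In this assay the ester of compound 1 proves to be a sensitive place: turning methoxycarbonyl into ethoxycarbonyl gives an 11-fold higher number from compound 1 to compound 4 (1.05 log units; beyond the scatter) and counts as a large step, although the change is only methyl in place of hydrogen on a saturated chain carbon bound to an oxygen next to a carbonyl group. The earlier exchange on compound 1, which gave a 2.1-fold higher number from compound 1 to compound 2 (0.32 log units; beyond the scatter) as a modest step, lay elsewhere in the molecule and gave no sign that the ester would respond this strongly. Nothing at hand accounts for the size of this rise in the number.

The compounds shown leave open whether a longer chain such as propoxycarbonyl would raise the number further, and whether a carboxylic acid or a primary amide in place of the ester would stay close to compound 1 or move away from it. They also leave open whether the same change from methoxycarbonyl to ethoxycarbonyl would have a similar effect on the cores of compound 2 and compound 3.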